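This account rests on a few compounds, and the source may have more. Where it says the series, first, only, none or still open, it means among the compounds named here.

Measured compounds and maximal responses:
- compound 1, `O=C(O)CCc1ccc(OCc2cccc(Br)c2)cc1`: 99%
- compound 2, `N#Cc1cccc(COc2ccc(CCC(=O)O)cc2)c1`: 102%
- compound 3, `O=C(O)CCc1ccc(OCc2cccc(-c3ccccc3)c2)cc1`: 105%

In a functional assay on 1321-N1 cells for agonist activity at Free fatty acid receptor 1 (Homo sapiens), read by calcium flux (a higher number here means a larger maximal response, a lower number a smaller maximal response), the three compounds sit in one band. Compound 3 carries the top number of the three, but the steps of a number 6 percentage points higher from compound 1 to compound 3 (within the scatter) and a number 3 percentage points higher from compound 2 to compound 3 (within the scatter) are both within the scatter, as is a number 3 percentage points higher from compound 1 to compound 2 (within the scatter); exchanging the substituent on the outer ring among bromo, cyano and phenyl has not shifted the maximal response in a way that can be told from noise.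

Compound 4, `COc1ccccc1-c1cccc(COc2ccc(CCC(=O)O)cc2)c1`, has not yet been measured. It differs from compound 3 as follows:
methoxy in place of hydrogen on an aromatic carbon

Among the compounds with values here, no measured step alters the phenyl group itself, so the bearing of the three steps is indirect: they show that this position of the core tolerates three different groups with a full maximal response each time. On that basis the step of a number 5 percentage points lower from compound 3 to compound 4 (within the scatter) from compound 3 to compound 4 is expected to stay within the scatter. For compound 4 the maximal response is estimated at 100%, with a range from 85% to 115%.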

Compound 4, largest response reached (reported as efficacy), in percent of the reference or control that the assay uses: 105%
The estimate for compound 4 lay 5 percentage points below the measured number, within the range that was stated.
By their numbers in this assay, from the lowest: compounds 1, 2, 3 and 4 (each within the scatter of the next).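

In this assay, within the data shown here, phenyl to 2-methoxyphenyl is the first change on the outer phenyl itself, and it gives no change at the digits printed from compound 3 to compound 4 (within the scatter). Methoxy on an aromatic carbon ortho to a large group is therefore tolerated here with the maximal response retained, which the exchanges among bromo, cyano and phenyl could not show. Compared with the smaller groups, the result is a number 3 percentage points higher from compound 2 to compound 4 (within the scatter) and a number 6 percentage points higher from compound 1 to compound 4 (within the scatter), so 2-methoxyphenyl joins the same band, and no measurement available explains this flat response.

From the compounds shown here alone, an amine, a carboxylic acid or a longer chain on the outer ring remains open, as does whether any group at this position can lower the maximal response. Maximal response alone also says nothing about potency across the series.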